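The source may hold more compounds than are shown below. What is called first, only, known or untested is meant among the compounds shown, and "the series" means these compounds.

Working notes on the series. In a functional assay on MCF7 cells (Homo sapiens) for inhibition, read by MTT assay (on this read-out higher numbers stand for weaker inhibition of growth and lower numbers for stronger inhibition of growth), compound 1 (`COc1cc2oc(-c3cccc(NC(=O)c4cccc(Br)c4)c3)cc(=O)c2c(OC)c1OC`) gives 6340 nM and compound 2 (`COc1ccc(C(=O)Nc2cccc(-c3cc(=O)c4c(OC)c(OC)c(OC)cc4o3)c2)cc1`) gives 6870 nM while compound 3 (`COc1cc2oc(-c3cccc(NC(=O)c4cccc(Br)c4)c3)cc(=O)c2c(O)c1OC`) gives 6940 nM on the same read-out. These three values lie within the scatter of one another, so compound 3 stands level with the other two.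

The next structure is compound 4 (`COc1ccc(C(=O)Nc2cccc(-c3cc(=O)c4c(O)c(OC)c(OC)cc4o3)c2)cc1`), which differs from compound 3 as follows: 4-methoxyphenyl in place of 3-bromophenyl on a carbonyl carbon. The same exchange has one measured precedent, a 1.1-fold higher number from compound 1 to compound 2 (0.03 log units; within the scatter), and that step stays within the scatter. The other measured step, hydrogen in place of methyl on an oxygen on an aromatic ring, gave a 1.1-fold higher number from compound 1 to compound 3 (0.04 log units; within the scatter), also within the scatter.

No step beyond the scatter is therefore expected in this assay for this exchange. The expected step is a 1.0-fold higher number from compound 3 to compound 4 (0.02 log units; within the scatter), with no clear direction. Compound 4 is expected at 7200 nM (estimated range 3800 nM to 13000 nM).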

Compound 4, concentration for 50% growth inhibition: 2050 nM
Compound 4: the middle estimate sits 3.5-fold (0.55 log units) above what was measured; the measured number lies below the stated range.
By their numbers in this assay, from the lowest: compound 4; then compounds 1, 2 and 3 (each within the scatter of the next).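

The exchange of 3-bromophenyl for 4-methoxyphenyl on a carbonyl carbon, silent on the core of compound 1, gives a 3.4-fold lower number from compound 3 to compound 4 (0.53 log units; beyond the scatter), so its outcome depends on the core that carries it: the same change on two cores in this assay, a 1.1-fold higher number (0.03 log units; within the scatter) from compound 1 to compound 2 and a 3.4-fold lower number (0.53 log units; beyond the scatter) from compound 3 to compound 4, 3.7-fold (0.56 log units) apart, beyond the scatter of two such steps

Read the other way, hydrogen in place of methyl on an oxygen on an aromatic ring gives a 3.4-fold lower number from compound 2 to compound 4 (0.53 log units; beyond the scatter), so that change also depends on the group on the carbonyl carbon: the same change on two cores in this assay, a 1.1-fold higher number (0.04 log units; within the scatter) from compound 1 to compound 3 and a 3.4-fold lower number (0.53 log units; beyond the scatter) from compound 2 to compound 4, 3.7-fold (0.56 log units) apart, beyond the scatter of two such steps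

The two changes therefore count only together in these four compounds: compound 4, which carries both, stands apart at 2050 nM.

Going by these compounds, whether the lower number rests on the methoxy group, on the loss of bromine or on both stays open. On these data alone, how an amine or a carboxylic acid in place of that methoxy group would read in this assay also stays open.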